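A Methyl Added to the Nitrophenyl Amide

This account rests on a few compounds, and the source may have more. Where it says the series, first, only, none or still open, it means among the compounds named here.

Measured so far:
compound 1 `CCn1cc(C(=O)Nc2ccccc2N)c(=O)c2cc(F)c(N3CCNC(C)C3)c(F)c21`: 2800 nM
compound 2 `CCn1cc(C(=O)Nc2cccc([N+](=O)[O-])c2)c(=O)c2cc(F)c(N3CCNC(C)C3)c(F)c21`: 1700 nM

In a functional assay on KB cells (Homo sapiens) for cytotoxicity, read by MTT assay (a lower number here means a stronger inhibitor, a higher number a weaker inhibitor), compound 2 gives 1700 nM. On the numbers shown compound 2 sits at the lower end, but its only neighbour, compound 1, gives 2800 nM, and the step of a 1.6-fold lower number from compound 1 to compound 2 (0.22 log units; within the scatter) is within the scatter, so the two compounds are not really told apart.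

Compound 3 `CCn1cc(C(=O)Nc2ccc(C)c([N+](=O)[O-])c2)c(=O)c2cc(F)c(N3CCNC(C)C3)c(F)c21` differs from compound 2 by methyl in place of hydrogen on an aromatic carbon: a methyl in place of hydrogen on an aromatic carbon, ortho to a nitro group. Within the data shown here, no measured step adds a methyl to this ring; the one step available swaps the whole substituent on the ring and stays within the scatter. Nothing therefore points to a shift beyond the scatter, and the step of a 1.1-fold lower number from compound 2 to compound 3 (0.05 log units; within the scatter) is expected to be small. Compound 3 is estimated at 1500 nM, with a range from 600 nM to 4000 nM in this assay.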

Compound 3, half-maximal inhibitory concentration: 3900 nM
The estimate for compound 3 lay 2.6-fold (0.41 log units) below the measured number; measured number inside the range.
By their numbers in this assay, from the lowest: compounds 2, 1 and 3 (each within the scatter of the next, the first and the last beyond it).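

In this assay, among these compounds, methyl in place of hydrogen on the aromatic carbon ortho to a nitro group gives a 2.3-fold higher number from compound 2 to compound 3 (0.36 log units; beyond the scatter) in what is a modest step, yet it is the first step to clear the scatter. So this ring carbon is a place where even a single methyl can register in the read-out. Measured against the 2-aminophenyl amide, the picture is different: a 1.4-fold higher number from compound 1 to compound 3 (0.14 log units; within the scatter) leaves those two compounds not told apart. Nothing available explains the effect of the methyl.

The compounds shown leave open whether a chlorine atom, an ethyl chain or a methoxy group on this same carbon would shift the number further or reverse the step. They also leave open how the methyl would read with a carboxylic acid in place of the nitro group.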